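The source may hold more compounds than are shown below. What is called first, only, known or untested is meant among the compounds shown, and "the series" means these compounds.

Compound 1 `COc1ccc(-c2ccc(C)n2-c2ccc(-c3nc4ccc(F)cc4s3)cc2)cc1` gives 19000 nM in a functional assay on MDA-MB-231 cells (Homo sapiens) for cytotoxicity, read by MTT assay, with a stated time of 72 h (on this read-out lower numbers stand for stronger inhibition and higher numbers for weaker inhibition), the highest of the two numbers recorded, though the nearest, compound 2 `Cc1ccc(-c2ccc([N+](=O)[O-])cc2)n1-c1ccc(-c2nc3ccc(F)cc3s2)cc1` with 17000 nM in this assay, lies within the scatter; the step of a 1.1-fold lower number from compound 1 to compound 2 (0.05 log units; within the scatter) is the only one measured. Compound 3 `COc1ccc(-c2ccc(C)n2-c2ccc(-c3nc4ccc(OC)cc4s3)cc2)cc1` differs from compound 1 by methoxy in place of fluoro on an aromatic carbon. Going by the values given here, no measured step touches this position, and the one known change at another place stayed within the scatter, so the account expects no step beyond the scatter. Compound 3 is therefore estimated at 19000 nM in this assay, from 7000 nM to 50000 nM, a step of no change at the digits printed from compound 1 to compound 3 (within the scatter).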

Compound 3, half-maximal inhibitory concentration: 12700 nM
Beside the measured number, compound 3's estimate is 1.5-fold (0.17 log units) above it; low and high end bracket the measured number.
By their numbers in this assay, from the lowest: compounds 3, 2 and 1 (each within the scatter of the next).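

Methoxy in place of fluoro is the first change measured at this position on the shared core, and in this assay it stays within the scatter (a 1.5-fold lower number from compound 1 to compound 3 (0.17 log units; within the scatter)). This position, like the one changed from compound 1 to compound 2, has so far shown no step beyond the scatter. No measurement on hand accounts for this result. The compounds shown leave open whether an amine or a carboxylic acid at this place would give a step beyond the scatter, and whether methoxy in place of fluoro would read the same on compound 2.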